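The compounds below may be only part of what the source reports. "The series", "measured", "known", "first", "only" and "open" are said of these compounds alone.

Compound 1, `CCC(=O)c1c(C)nn(CCCN2CCN(c3ccc(C)cc3)CC2)c(=O)c1N`: 29%
Compound 2, `CCCCC(=O)c1c(C)nn(CCCN2CCN(c3ccc(C)cc3)CC2)c(=O)c1N`: 15%

In a functional assay on the whole organism (Abdomen, strain Swiss) for inhibition, with Mus musculus as the target, with stated times of 30 min, 10 min and 5 min, at a dose of 40 mg/kg by the oral route (a higher number here means a stronger effect of the compound at the dose given, a lower number a weaker effect), compound 1 gives 29% and compound 2 gives 15%. Compound 2 stands lowest of the two numbers, with compound 1 as its nearest neighbour. Among the compounds with values here, the only measured step, a number 14 percentage points lower from compound 1 to compound 2 (beyond the scatter), came with ethyl in place of hydrogen on a saturated chain carbon, two bonds along the chain from a carbonyl carbon.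

Compound 3, `C/C=C/c1c(C)nn(CCCN2CCN(c3ccc(C)cc3)CC2)c(=O)c1N`, differs from compound 2 by prop-1-en-1-yl in place of butylcarbonyl on an aromatic carbon. Within the data shown here, no measured step touches the carbonyl itself, so the one step bears on the change only loosely: a longer chain lowered the number modestly, and the chain now becomes shorter. For this assay a small rise is expected, possibly within the scatter. Compound 3 is therefore estimated at 22%, between 5% and 40%, which means an expected step of a number 7 percentage points higher from compound 2 to compound 3 (within the scatter).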

Compound 3, a percentage reported as inhibition, in the whole organism at one dose (the size of the read-out at that dose, not a potency): 63%
For compound 3 the middle estimate is 41 percentage points below the measured one, and the stated range ends below it.
By their numbers in this assay, from the lowest: compound 2; then compound 1; then compound 3.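

In this assay this position, opposite the ring nitrogen, responds far more strongly to a change in the kind of group than the earlier change in chain length suggested: prop-1-en-1-yl in place of butylcarbonyl gives a number 48 percentage points higher from compound 2 to compound 3 (beyond the scatter) and prop-1-en-1-yl in place of propanoyl gives a number 34 percentage points higher from compound 1 to compound 3 (beyond the scatter) in the same direction. Both steps are large, whereas the step between the two compounds bearing a carbonyl at this position was modest, so the group without a carbonyl stands apart from both of them. Nothing available explains this rise.

The compounds shown leave open whether the rise goes with the loss of the carbonyl, the smaller group or the alkene itself. On these data alone, how a saturated propyl group or a longer pent-1-en-1-yl chain would read at this position also remains open.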